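The source may hold more compounds than are shown below. What is called first, only, known or untested is meant among the compounds shown, and "the series" means these compounds.

Among the measured compounds shown here, in an ADME assay on microsomes (Homo sapiens) for metabolic stability (on this read-out higher numbers stand for a longer-lived compound and lower numbers for a shorter-lived compound), the compounds measured so far read as follows.

Compound 1 `CCC(=O)N1CCC(C(=O)N2N=CCC2c2ccccc2)CC1` gives > 2.75 h as a limit
Compound 2 `O=C(C1CCN(c2ccccc2)CC1)N1N=CCC1c1ccccc1` gives > 1.5 h as a limit
Compound 3 `N#Cc1nccc(N2CCC(C(=O)N3N=CC[C@H]3c3cc(F)cc(F)c3)CC2)n1` gives 2.1 h as a number

Compound 2 therefore has no exact place on the scale of this assay because its entry of > 1.5 h is a limit and not a number. Compound 4 `O=C(c1cc[nH]n1)N1CCC(C(=O)N2N=CCC2c2ccccc2)CC1` differs from compound 2 in one place, with (1H-pyrazol-3-yl)carbonyl in place of phenyl on an amine nitrogen in a ring. For the measured compounds named here, the only measured step at that place is a step that the two limits leave unreadable from compound 1 to compound 2 and so it gives no size to carry over. Going by the values given here, the only plain number here is that of compound 3 at 2.1 h and so, although compound 3 differs from compound 4 in more than one place, no step beyond the scatter is expected and no direction can be named. The estimated change is a step that the limit leaves unreadable from compound 2 to compound 4 and it is expected to stay within the usual scatter. For compound 4 the estimate is 2.4 h with an expected range from 1.2 h to 4.8 h in this measurement.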

Compound 4, half-life: > 2.75 h
Compound 4 was reported as a limit (the forecaster's own chance of this, stated with the estimate: 45%); at least 1.1-fold (0.05 log units) between middle value and limit.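

In this assay, compound 4 is reported as a limit and not a number, as are compound 1 and compound 2, so no step among these compounds can be read. The compounds shown leave open whether changing the group on the amine nitrogen in a ring alters half-life at all.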